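The source may hold more compounds than are shown below. What is called first, only, known or untested is meant among the compounds shown, and "the series" means these compounds.

Compound 2 `Cc1cc(C#N)cc(C)c1Oc1nc(Nc2ccc(C#N)cc2)ncc1/C=C/C(=O)NC1CCN(C(=O)C(F)(F)F)CC1` was tested in an ADME assay on TZM cells (Homo sapiens) for cytotoxicity, with a stated time of 1 days; on this read-out higher numbers stand for lower toxicity in this test and lower numbers for higher toxicity in this test. In this assay compound 2 gives only a limit of the assay, > 170 nM, and not a number. Compound 1 `COCCNC(=O)/C=C/c1cnc(Nc2ccc(C#N)cc2)nc1Oc1c(C)cc(C#N)cc1C`, which differs from compound 2 only in the group on an amide-type nitrogen, was tested in the same assay. There compound 1 also gives only a limit, > 213 nM. The step that the two limits leave unreadable from compound 1 to compound 2 therefore cannot be read, since both values are limits (the limit of > 170 nM in this assay, at which 1 of the 2 values shown sits, and (the limit of > 213 nM in this assay, at which 1 of the 2 values shown sits)). Compound 3 `Cc1cc(C#N)cc(C)c1Oc1nc(Nc2ccc(C#N)cc2)ncc1/C=C/C(=O)NC1CCN(S(C)(=O)=O)C1` carries the change (1-(methylsulfonyl)pyrrolidin-3-yl in place of 1-((trifluoromethyl)carbonyl)piperidin-4-yl on an amide-type nitrogen), that is 1-(methylsulfonyl)pyrrolidin-3-yl in place of 1-((trifluoromethyl)carbonyl)piperidin-4-yl on an amide-type nitrogen whose other neighbour is a carbonyl carbon. Among the measured compounds shown here, the only measured step touches the same amide-type nitrogen, but its size is not readable, so it gives no direction to expect. The step that the limit leaves unreadable from compound 2 to compound 3 is therefore expected to stay within the scatter. The estimate for compound 3 in this assay is 250 nM, ranging from 100 nM to 1000 nM, and most likely the assay again reports only a limit.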

Compound 3, half-maximal cytotoxic concentration: > 179 nM
Compound 3 was reported as a limit (the forecaster's own chance of this, stated with the estimate: 80%); the middle value is on the limit's open side.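

In this assay compound 1, compound 2 and compound 3 all give only limits of the assay and not numbers, so no step among these three compounds can be read. The compounds shown leave open where the real half-maximal cytotoxic concentration of each lies, and whether changing the group on the amide-type nitrogen shifts it at all.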